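The compounds below may be only part of what the source reports. "The series", "measured", "known", "first", "only" and "open" are said of these compounds alone.

Working notes on the sulfonyl guanidine series with the phenylpropynylidene hydrazone arm.

Two compounds carry numbers. Compound 1 `Cc1cccc(CSc2cc(Cl)c(C)cc2S(=O)(=O)/N=C(\N)N/N=C/C#Cc2ccccc2)c1` in a functional assay on HeLa cells (Homo sapiens) for antiproliferative activity, read by MTT assay, with a stated time of 72 h (a higher number here means a weaker inhibitor, a lower number a stronger inhibitor), gives 11000 nM. Compound 2 `C/C(C#Cc1ccccc1)=N\N/C(N)=N/S(=O)(=O)c1cc(C)c(Cl)cc1SCc1cccc(C(F)(F)F)c1` in this assay gives 18000 nM, the higher of the two numbers, with compound 1 the nearest at a gap that lies within the scatter; the two compounds are therefore read as indistinguishable.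

Compound 3 `C/C(C#Cc1ccccc1)=N\N/C(N)=N/S(=O)(=O)c1cc(C)c(Cl)cc1SCc1cccc2ccccc12` is not yet measured. It differs from compound 2 in one place: naphthalen-1-yl in place of 3-(trifluoromethyl)phenyl on a saturated chain carbon bound to a sulfur. Among the measured compounds shown here, no comparison between measured compounds covers an exchange of this kind, so nothing here shows how such a change moves the number, and the expectation rests only on compound 2. The step from compound 2 to compound 3 is expected to be a 1.2-fold lower number from compound 2 to compound 3 (0.08 log units; within the scatter), with no direction beyond the scatter. Compound 3 is accordingly estimated at 15000 nM, with a range from 6000 nM to 40000 nM.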

Compound 3, half-maximal inhibitory concentration: 125000 nM
The estimate for compound 3 lay 8.3-fold (0.92 log units) below the measured number; the whole stated range lies below it.
By their numbers in this assay, from the lowest: compounds 1 and 2 (each within the scatter of the next); then compound 3.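

In this assay, this position on a saturated chain carbon bound to a sulfur proves sensitive to the aryl group it carries: naphthalen-1-yl in place of 3-(trifluoromethyl)phenyl gives a 6.9-fold higher number from compound 2 to compound 3 (0.84 log units; beyond the scatter). Among the compounds shown here, the shift arises although the leaving and entering groups have the same count of heavy atoms and neither has hydrogen-bond donors or acceptors, and the earlier compounds offered no single-place step that could show it. Nothing measured here bears on the reason for this step.

As far as these compounds go, whether the step follows the loss of the trifluoromethyl group or the entry of the second aromatic ring remains open. A plain phenyl group on the same carbon, read against compounds 2 and 3, would begin to separate these two parts of the exchange.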